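The source may hold more compounds than are shown below. What is called first, only, known or untested is meant among the compounds shown, and "the series" means these compounds.

Values in an ADME assay on microsomes from liver (Homo sapiens) for metabolic stability; a higher number here means faster removal of the compound, a lower number slower removal:
Compound 1 `CC(=O)N[C@@H]1CCC[C@H](C(=O)Nc2cc(-c3cnn4c3CCCC4)c(F)cn2)C1`: < 3 mL.min-1.g-1 (a limit)
Compound 2 `CC(=O)N[C@@H]1CCC[C@H](C(=O)Nc2cc(-c3cnn4c3CC(C)(C)C4)ccn2)C1`: < 3 mL.min-1.g-1 (a limit)
Compound 3 `CC(=O)N[C@@H]1CCC[C@H](C(=O)Nc2cc(-c3cnn4c3CC(C)(C)C4)c(F)cn2)C1`: 19 mL.min-1.g-1

Among the measured compounds shown here, compound 3 carries the only true number of the three, and the highest. Compound 4 `CC(=O)N[C@@H]1CCC[C@H](C(=O)Nc2cc(-c3cnn4c3CC(C)(C)C4)c(C#N)cn2)C1` departs from it as follows: cyano in place of fluoro on an aromatic carbon. This puts cyano in place of fluoro on an aromatic carbon. For the measured compounds named here, no measured step makes this exchange. The closest is an at least 6.3-fold higher number from compound 2 to compound 3 (0.80 log units; beyond the scatter), where fluoro replaced hydrogen on that same carbon, a step beyond the scatter. The step of an at least 6.3-fold higher number from compound 1 to compound 3 (0.80 log units; beyond the scatter) lies elsewhere in the structure and bears on it less. The first shows that this carbon can matter, but not what cyano will do. The expected step is a 1.9-fold lower number from compound 3 to compound 4 (0.28 log units; within the scatter), small and probably not beyond the scatter. For compound 4 the estimated value in this assay is 10 mL.min-1.g-1, with an expected range of 3 mL.min-1.g-1 to 30 mL.min-1.g-1.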

Compound 4, intrinsic clearance in microsomes in the Homo sapiens assay: 26 mL.min-1.g-1
Beside the measured number, compound 4's estimate is 2.6-fold (0.41 log units) below it; low and high end bracket the measured number.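

In the Homo sapiens assay compound 3 gives 19 mL.min-1.g-1 and compound 4 gives 26 mL.min-1.g-1, so cyano and fluoro on this carbon cannot be told apart: a 1.4-fold higher number from compound 3 to compound 4 (0.14 log units; within the scatter). Cyano in place of hydrogen also gives a step beyond the scatter, an at least 8.6-fold higher number from compound 2 to compound 4 (0.93 log units; beyond the scatter), so the higher number at this carbon is not confined to fluoro. In a physicochemical assay for lipophilicity, using the shake flask method, measured as octanol-water partition, at pH 7.4 (on this read-out lower numbers stand for lower lipophilicity and higher numbers for higher lipophilicity), compound 3 gives 3.3 and compound 4 gives 3.2, and the exchange also stays within the scatter, a number 0.10 log units lower from compound 3 to compound 4 (within the scatter).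

On these data alone, compound 2 stands at a limit, so the full size of the rise stays open: the limit of < 3 mL.min-1.g-1 in the Homo sapiens assay, at which 2 of the 4 values shown sit. As far as these compounds go, whether a methoxy group or an amine on this carbon would also give a higher number remains open.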